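The source may report more compounds than this note shows. Statements on the series, on what has been measured and on what is new or still open speak of the compounds shown alone.

Measured so far:
compound 1 `NS(=O)(=O)c1ccc(-c2nc(C(c3ccc(F)cc3)c3ccc(F)cc3)sc2CC(=O)O)cc1` — in an in vitro functional assay on HEK285-7 cells for antagonist activity at prostaglandin D2 receptor 2 (Homo sapiens), read by BRET and beta-arrestin recruitment (on this read-out higher numbers stand for larger maximal responses and lower numbers for smaller maximal responses), compound 1 gives 80%
compound 2 `O=C(O)Cc1sc(C(c2ccc(F)cc2)c2ccc(F)cc2)nc1-c1cccc(F)c1` — compound 2 gives 80%
compound 3 `O=C(O)Cc1sc(C(c2ccc(F)cc2)c2ccc(F)cc2)nc1-c1cn[nH]c1` — compound 3 gives 80%

Compound 3 stands level with compounds 1 and 2 at the digits shown; all three fall within the usual scatter of one another. The next compound is compound 4 `O=C(O)Cc1sc(C(c2ccc(F)cc2)c2ccc(F)cc2)nc1-c1ccccc1`, and the change from compound 3 is phenyl in place of 1H-pyrazol-4-yl on an aromatic carbon. Every measured step touched this same position: no change at the digits printed from compound 1 to compound 2 (within the scatter), no change at the digits printed from compound 1 to compound 3 (within the scatter) and no change at the digits printed from compound 2 to compound 3 (within the scatter), none of them reaching beyond the scatter. Three different groups at this carbon left the maximal response unchanged, so a phenyl here is expected to do the same, with an expected step of no change at the digits printed from compound 3 to compound 4 (within the scatter). Compound 4 is therefore estimated at 80%, within a range from 70% to 90%.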

Compound 4, largest response reached (reported as efficacy), in percent of the reference or control that the assay uses: 80%
Beside the measured number, compound 4's estimate shows no gap at the digits printed, and the stated range covers the measured number.
By their numbers in this assay, from the lowest: compounds 1, 2, 3 and 4 (each within the scatter of the next).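

In this assay there is no change at the digits printed from compound 3 to compound 4 (within the scatter) when phenyl replaces 1H-pyrazol-4-yl, so the maximal response holds on this aromatic carbon with a ring carrying 0 hydrogen-bond donors and 0 hydrogen-bond acceptors. There is also no change at the digits printed from compound 2 to compound 4 (within the scatter) with hydrogen in place of fluoro and no change at the digits printed from compound 1 to compound 4 (within the scatter) with hydrogen in place of sulfamoyl, so the unsubstituted phenyl holds the response without either group. No measured evidence explains why the response stays level.

Every group shown here is an aromatic ring, so it remains open whether a methyl, a morpholine or a longer chain on this carbon would hold the response too.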